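A few compounds are considered here, and "the series" means these few. Any claim that something is new, unique, unknown or untested is made for them only; others in the source may bear on it.

The series gathers a small set of compounds around one shared core and tests them in a functional assay on the whole organism (stomach) with Rattus norvegicus as the target; on this read-out higher numbers stand for an effect only at larger amounts of compound and lower numbers for an effect already at smaller amounts. For the measured compounds named here, compound 1, `CC/N=C(\S)CCn1nc(-c2ccccc2)ccc1=O`, is the anchor of the account: in this assay compound 1 gives 100 mg/kg, and this is the only outright number the set holds. Going by the values given here, the single other value is a limit of the assay rather than a number. That limit belongs to compound 2, `N=C(S)CCn1nc(-c2ccc(Cl)cc2)ccc1=O`, which in this assay reaches only > 100 mg/kg; the entry the limit of > 100 mg/kg in this assay, at which 1 of the 2 values shown sits, marks it as a limit. Among the compounds with values here, no pair of measured compounds differs in a single place, so no measured step is available, and the two values can be read only side by side.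

Compound 3, `N=C(S)CCCCCn1nc(-c2ccccc2)ccc1=O`, has not yet been tested in this assay. Its departure from compound 1 is a group of 6 heavy atoms (4 carbon, 1 nitrogen, 1 sulfur; no ring) in place of a group of 5 heavy atoms (3 carbon, 1 nitrogen, 1 sulfur; no ring), on a saturated chain carbon, two bonds along the chain from an aromatic nitrogen. With nothing measured along a comparable step, the expected change from compound 1 to compound 3 is set at a 1.2-fold higher number from compound 1 to compound 3 (0.08 log units; within the scatter), a shift not expected to go beyond the scatter. On that basis compound 3 is estimated to give 120 mg/kg in this assay, with a range from 50 mg/kg to 300 mg/kg.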

Compound 3, dose for half-maximal effect: 23.3 mg/kg
Estimate against measurement, compound 3: 5.2-fold (0.71 log units) above, outside the stated range (below it).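

The step gives the series its first measured change, and it falls on a saturated chain carbon, two bonds along the chain from an aromatic nitrogen: in this assay the swap brings a 4.3-fold lower number from compound 1 to compound 3 (0.63 log units; beyond the scatter). The reading at this place therefore responds to the group it carries, which neither compound 1 nor compound 2 could show alone, and here the change runs towards an effect at smaller amounts of compound. The entering group differs from the leaving one both in its carbon count and in its hydrogen-bond donors, this single step cannot part the two, and nothing measured here bears on why the reading moved.

The compounds shown do not tell whether a longer chain would carry the change further, or whether an amine or a carboxylic acid at the end of the chain would keep it. For the compounds shown here, the entry for compound 2, > 100 mg/kg, remains a limit of the assay and not a number, and it joins no step.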